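The source may hold more compounds than are shown below. What is called first, only, known or untested is meant among the compounds shown, and "the series" means these compounds.

Measured in a functional assay on A549 cells (Homo sapiens) for antiproliferative activity, read by MTT assay, with a stated time of 48 h; a higher number here means a weaker inhibitor of growth, a lower number a stronger inhibitor of growth

Compound 1 `COC(=O)N1N=C(c2ccccc2)CC1c1cc(OC)c(OC)c(OC)c1` gives 2880 nM
Compound 2 `CCOC(=O)N1N=C(c2ccccc2)CC1c1cc(OC)c(OC)c(OC)c1` gives 6680 nM

Compound 2 stands highest of these two numbers, at 6680 nM, and so is the weaker inhibitor of growth in this assay. Compound 3 `CCCOC(=O)N1N=C(c2ccccc2)CC1c1cc(OC)c(OC)c(OC)c1` extends its ester chain from ethoxy to propoxy: methyl in place of hydrogen on a saturated chain carbon, two bonds along the chain from an oxygen next to a carbonyl group, with methyl in place of hydrogen on a saturated chain carbon, two bonds along the chain from an oxygen next to a carbonyl group. For the measured compounds named here, only one measured step bears on this change: a 2.3-fold higher number from compound 1 to compound 2 (0.37 log units; beyond the scatter). There, methyl also replaced hydrogen, on the chain carbon bound to that oxygen, and the step was modest. A single step sets no trend, but a further modest rise is expected. The expected change is a 1.5-fold higher number from compound 2 to compound 3 (0.18 log units; within the scatter). For compound 3 the estimate is 10000 nM, within an expected range of 4500 nM to 22000 nM.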

Compound 3, concentration for 50% growth inhibition: > 10000 nM
Compound 3: no number, only a limit; the forecaster's own chance of this, stated with the estimate: 10%; the middle value sits exactly at the limit.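

In this assay compound 3 gives > 10000 nM, which is a limit of the assay and not a number. The change from ethoxy to propoxy reads an at least 1.4-fold higher number from compound 2 to compound 3 (0.17 log units; that floor lies within the scatter), so this step alone establishes no further loss, whereas the full extension of the ester chain reads an at least 3.4-fold higher number from compound 1 to compound 3 (0.54 log units; beyond the scatter), which shows that the loss seen earlier is not recovered at the longer chain. The size of the last step stays unknown, and with it whether the rise continues at the same pace: the limit of > 10000 nM in this assay, at which 1 of the 3 values shown sits.

The compounds shown leave open whether a branched isopropoxy chain would keep the number closer to that of compound 1. They also leave open whether an amine in place of the alkoxy group on the carbonyl would bring growth inhibition back.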